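The source may hold more compounds than are shown below. What is called first, only, known or untested is meant among the compounds shown, and "the series" means these compounds.

Compound 1 `Cc1cc(Cl)ccc1-c1cccc(COc2ccc([C@H](CC(=O)O)c3ncnn3C)cc2)c1` and compound 2 `Cc1cc(Cl)ccc1-c1cccc(COc2ccc([C@H](CC(=O)O)c3nnnn3C)cc2)c1` share one core, while compound 3 `Cc1nc(-c2ccc(C(F)(F)F)cc2)sc1COc1ccc([C@H](CC(=O)O)c2ncnn2C)cc1` and the not yet measured compound 4 `Cc1nc(-c2ccc(C(F)(F)F)cc2)sc1COc1ccc([C@H](CC(=O)O)c2nnnn2C)cc1` share another; the difference between the two cores is not broken down here. In an ADME assay on the whole organism for pharmacokinetics, with Rattus norvegicus as the target, at a dose of 0.5 mg/kg by the intravenous route (on this read-out higher numbers stand for fast clearance and lower numbers for slow clearance), compound 1 gives 25 mL/min/kg. In this assay compound 2 gives 46.7 mL/min/kg, so the change 1-methyl-1H-tetrazol-5-yl in place of 1-methyl-1H-1,2,4-triazol-5-yl on a saturated chain carbon bound to an aromatic carbon and a saturated chain carbon gave a 1.9-fold higher number from compound 1 to compound 2 (0.27 log units; within the scatter). In this assay compound 3 gives 7.67 mL/min/kg, the lowest number of the three measured compounds. Compound 4 carries the same change on the same place, (1-methyl-1H-tetrazol-5-yl in place of 1-methyl-1H-1,2,4-triazol-5-yl on a saturated chain carbon bound to an aromatic carbon and a saturated chain carbon), and is still to be measured in this assay. Among the measured compounds shown here, since the only measured example of this change is the small move from compound 1 to compound 2, namely a 1.9-fold higher number from compound 1 to compound 2 (0.27 log units; within the scatter), a step of similar size, a 1.5-fold higher number from compound 3 to compound 4 (0.18 log units; within the scatter), is expected from compound 3 to compound 4. On that basis compound 4 is estimated to give about 11.5 mL/min/kg in this assay, most likely between 6 mL/min/kg and 22 mL/min/kg.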

Compound 4, clearance: 71.7 mL/min/kg
Compound 4: the middle estimate sits 6.2-fold (0.79 log units) below what was measured; measured number outside the range, above it.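

Placing 1-methyl-1H-tetrazol-5-yl where 1-methyl-1H-1,2,4-triazol-5-yl stood had a large effect on the second core: in this assay, the change gave a 9.3-fold higher number from compound 3 to compound 4 (0.97 log units; beyond the scatter). Set beside the earlier step, the same change clearly did not carry over with the same size from one core to the other: the same change on two cores in this assay, a 1.9-fold higher number (0.27 log units; within the scatter) from compound 1 to compound 2 and a 9.3-fold higher number (0.97 log units; beyond the scatter) from compound 3 to compound 4, 5.0-fold (0.70 log units) apart, beyond the scatter of two such steps These two pairs show that the size of this step depends on the core, so a step read on one core is a poor guide to the other, but they do not show which part of the core matters or how the change would behave on a third core.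

The compounds shown leave open which of the differences between the two cores sets the size of the step. They also leave open whether a nitrile or a primary amide, placed on the same saturated chain carbon, would give a number nearer that of compound 3 or that of compound 4.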